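The source may report more compounds than this note shows. Statements on the series, on what has been measured and on what is new or still open speak of the compounds shown alone.

Compound 1, `COc1nc(C)c(Nc2nc(Cl)cn([C@H](COC(=O)c3ccccn3)C3CC3)c2=O)cc1C`: in an assay on frontal cortex for displacement of a labelled ligand from corticotropin-releasing factor receptor 1 (Rattus norvegicus), with a stated time of 2 h (a higher number here means a weaker inhibitor, a lower number a stronger inhibitor), compound 1 gives 67 nM.
Compound 2, `COc1nc(C)c(Nc2nc(Cl)cn([C@H](COC(=O)c3cccnc3)C3CC3)c2=O)cc1C`: compound 2 gives 5.2 nM.
Compound 3, `COc1nc(C)c(Nc2nc(Cl)cn([C@H](COC(=O)Nc3cc(Cl)cc(Cl)c3)C3CC3)c2=O)cc1C`: compound 3 gives 1.7 nM.

These three compounds share one core and differ only in the group attached to a carbonyl carbon on a side chain. Compound 2 stands second highest of the three numbers: compound 3 is nearest, with a 3.1-fold lower number from compound 2 to compound 3 (0.49 log units; beyond the scatter), and compound 1 is furthest, the gap showing as a 13-fold lower number from compound 1 to compound 2 (1.11 log units; beyond the scatter).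

Compound 4, `CCCNC(=O)OC[C@H](C1CC1)n1cc(Cl)nc(Nc2cc(C)c(OC)nc2C)c1=O`, has not yet been tested. Relative to compound 2 it carries propylamino in place of pyridin-3-yl on a carbonyl carbon. Going by the values given here, two measured steps bear on this. The step of a 3.1-fold lower number from compound 2 to compound 3 (0.49 log units; beyond the scatter) shows a modest gain when an amino-linked group replaces pyridin-3-yl on that carbonyl carbon, and a 13-fold lower number from compound 1 to compound 2 (1.11 log units; beyond the scatter) shows that what sits on that carbon can move the number a great deal. Among the compounds with values here, compound 4 also places an amino-linked group there, but without any ring, a combination no measured pair covers. The expected step is therefore a 1.0-fold lower number from compound 2 to compound 4 (0.02 log units; within the scatter), nothing beyond the scatter, with wide uncertainty either way. Compound 4 is estimated to give 5 nM, between 1.5 nM and 20 nM.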

Compound 4, half-maximal inhibitory concentration: 10 nM
Compound 4: middle estimate off by 2.0-fold (0.30 log units), on the low side; the range from low to high includes it.
By their numbers in this assay, from the lowest: compound 3; then compounds 2 and 4 (each within the scatter of the next); then compound 1.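

In this assay, a group with no ring can serve on this carbonyl carbon: propylamino in place of pyridin-3-yl gives a 1.9-fold higher number from compound 2 to compound 4 (0.28 log units; within the scatter), which stays within the scatter, while propylamino in place of pyridin-2-yl gives a 6.7-fold lower number from compound 1 to compound 4 (0.83 log units; beyond the scatter), a clear gain. With the amino link kept, the group on the nitrogen still matters, since propyl in place of 3,5-dichlorophenyl gives a 5.9-fold higher number from compound 3 to compound 4 (0.77 log units; beyond the scatter), so the amino link alone does not account for the low number of compound 3. Nothing measured here explains why the numbers move in this way.

The compounds shown leave open how the number would respond to a shorter chain such as ethylamino, a longer one such as hexylamino, or a plain phenylamino, which would separate the effect of the ring from that of its two chlorine atoms. They also leave open whether the large gap from pyridin-2-yl to pyridin-3-yl would reappear with pyridin-2-ylamino and pyridin-3-ylamino on this carbonyl carbon.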